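A few compounds are considered here, and "the series" means these few. Any claim that something is new, unique, unknown or untested is made for them only; others in the source may bear on it.

Compound 1 `ClCc1ccccc1Cn1cnc2c(Cl)ncnc21`: 7410 nM
Compound 2 `ClCc1ccc(Cn2cnc3nc(Cl)nc(Cl)c32)cc1`: 7070 nM

In a functional assay on HCC 2998 cells (Homo sapiens) for cytotoxicity, read by sulforhodamine B assay, with a stated time of 48 h (a lower number here means that less compound is tolerated, a higher number that more compound is tolerated), compound 2 gives 7070 nM, and compound 1 gives 7410 nM, a number within the scatter of it, so the two cannot be told apart. Compound 3 `ClCc1ccc(Cn2cnc3ncnc(Cl)c32)cc1` has not been measured; it differs from compound 2 by hydrogen in place of chloro on an aromatic carbon. Among the compounds with values here, no measured pair shows this change, so its size is unknown, and a step no larger than the scatter seems most likely. Compound 3 is expected to give about 9000 nM, between 3500 nM and 25000 nM. That would mean an expected step of a 1.3-fold higher number from compound 2 to compound 3 (0.10 log units; within the scatter).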

Compound 3, concentration lethal to 50% of the cells: 5750 nM
Compound 3: the middle estimate sits 1.6-fold (0.19 log units) above what was measured, within the range that was stated.
By their numbers in this assay, from the lowest: compounds 3, 2 and 1 (each within the scatter of the next).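

In this assay, putting hydrogen in place of chloro on the aromatic carbon between two ring nitrogen atoms gives a 1.2-fold lower number from compound 2 to compound 3 (0.09 log units; within the scatter). Within the data shown here, this pair is the first reading of this change, and it shows that this chloro group can go without a difference that can be told from the scatter. No measurement at hand offers an explanation for this result. As far as these compounds go, what remains open is whether an amine or a methoxy group on this same carbon would also leave the number within the scatter. One pair also cannot show whether this holds on other cores.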